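The source may report more compounds than this note shows. Statements on the series, on what has been measured and on what is new or still open speak of the compounds shown alone.

Working notes on the series.

Two compounds share one core and differ only at a single oxygen. Compound 3 `COc1ccc(/C=C2\CCC/C(=C\c3ccc([N+](=O)[O-])cc3)C2=O)cc1OC` and compound 1 `COc1cc(/C=C2\CCC/C(=C\c3ccc([N+](=O)[O-])cc3)C2=O)ccc1O` are both measured in a functional assay on HSC-3 cells (Homo sapiens) for cytotoxicity; a lower number here means that less compound is tolerated, a higher number that more compound is tolerated. Compound 3 gives 4400 nM and compound 1 gives 5200 nM. The change between them is hydrogen in place of methyl on an oxygen on an aromatic ring and the step is a 1.2-fold higher number from compound 3 to compound 1 (0.07 log units; within the scatter), so within this pair the change does not move the half-maximal cytotoxic concentration in a way that can be told from repeat-to-repeat variation.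

Compound 2 `COc1ccc(/C=C2\Cc3ccccc3/C(=C\c3ccc([N+](=O)[O-])cc3)C2=O)cc1` carries a different core; the difference between the two cores is not broken down here. In this assay compound 2 gives 32000 nM, the highest of the three measured numbers, and the gap to compound 1 as well as to compound 3 lies beyond the scatter of the method.

Compound 4 `O=C1/C(=C/c2ccc(O)cc2)Cc2ccccc2/C1=C\c1ccc([N+](=O)[O-])cc1` is not yet measured. It relates to compound 2 as compound 1 relates to compound 3: the change is hydrogen in place of methyl on an oxygen on an aromatic ring, with the same surroundings at the place of change as in the measured pair, so it is the same change on a different core. Because the measured instance a 1.2-fold higher number from compound 3 to compound 1 (0.07 log units; within the scatter) stayed within the scatter, the corresponding step from compound 2 to compound 4 is expected to be small as well, estimated at a 1.2-fold higher number from compound 2 to compound 4 (0.07 log units; within the scatter). Compound 4 is therefore estimated at 38000 nM in this assay, with the expected range running from 16000 nM to 80000 nM.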

Compound 4, half-maximal cytotoxic concentration: 14000 nM
Compound 4: middle estimate off by 2.7-fold (0.43 log units), on the high side, and the stated range ends above it.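

In this assay, going from methoxy to hydroxy on the core of compound 2 gives a 2.3-fold lower number from compound 2 to compound 4 (0.36 log units; beyond the scatter), so on this core the change moves the half-maximal cytotoxic concentration by more than repeat-to-repeat variation. Set beside the earlier pair, the change does not carry over at one size from one core to the other: the same change on two cores in this assay, a 1.2-fold higher number (0.07 log units; within the scatter) from compound 3 to compound 1 and a 2.3-fold lower number (0.36 log units; beyond the scatter) from compound 2 to compound 4, 2.7-fold (0.43 log units) apart, beyond the scatter of two such steps. This shows that a step read on one of these pairs cannot simply be transferred to the other, but with one pair per core it gives no general rule, and it does not show that the core alone sets the difference, since compound 3 and compound 1 also keep a further methoxy on the same aromatic ring, which compound 2 and compound 4 lack.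

The compounds shown leave open whether the step on the core of compound 2 would look the same with that further methoxy present, and so whether the core or the ring substitution accounts for the gap. They also leave open how the same oxygen would behave with a longer chain such as ethoxy, or how the series would respond to an amine in place of the hydroxy.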